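The source may hold more compounds than are shown below. What is called first, only, known or untested is meant among the compounds shown, and "the series" means these compounds.

Working notes on a functional assay on MCF7 cells (Homo sapiens) for inhibition, read by sulforhodamine B assay, with a stated time of 48 h; on this read-out lower numbers stand for stronger inhibition of growth and higher numbers for weaker inhibition of growth. Compound 1 `COc1cc(-c2nn(-c3cccc(NC(=O)c4ccc(Cl)c(C(F)(F)F)c4)c3)cc2-c2ccncc2)ccc1Cl` reaches only a limit in this assay, > 32500 nM. Going by the values given here, compound 2 `COc1cc(-c2nn(-c3cccc(NC(=O)Nc4cccc(C(F)(F)F)c4)c3)cc2-c2ccncc2)ccc1Cl` gives 7720 nM, the only true number among the three values shown. Compound 3 `O=C(Nc1cccc(-n2cc(-c3ccncc3)c(-c3ccc(Cl)c(O)c3)n2)c1)Nc1cccc(C(F)(F)F)c1` again returns only a limit, > 32500 nM. Going by these compounds, both measured steps, an at least 4.2-fold lower number from compound 1 to compound 2 (0.62 log units; beyond the scatter) and an at least 4.2-fold higher number from compound 2 to compound 3 (0.62 log units; beyond the scatter), are bounded by the limit of > 32500 nM in this assay, at which 2 of the 3 values shown sit, so their true sizes remain open. Compound 4 `COc1cc(-c2nn(-c3cccc(NC(=O)Nc4ccc(Cl)c(Cl)c4)c3)cc2-c2ccncc2)ccc1Cl` is not yet measured; it differs from compound 2 by 3,4-dichlorophenyl in place of 3-(trifluoromethyl)phenyl on an amide-type nitrogen. Among the compounds with values here, the only step touching the same urea-bound aryl group is an at least 4.2-fold lower number from compound 1 to compound 2 (0.62 log units; beyond the scatter), which also changes the amide-to-urea linkage, so no clean precedent exists. For compound 4 the expected step is a 1.3-fold higher number from compound 2 to compound 4 (0.11 log units; within the scatter), within the scatter. Compound 4 is therefore estimated at 10000 nM, between 3500 nM and 32500 nM, with a fair chance of only a limit.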

Compound 4, concentration for total growth inhibition: > 50000 nM
Compound 4: no number, only a limit; the forecaster's own chance of this, stated with the estimate: 35%; middle value at least 5.0-fold (0.69 log units) away from the limit.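

In this assay the aryl group on this amide-type nitrogen matters to the read-out: 3,4-dichlorophenyl in place of 3-(trifluoromethyl)phenyl gives an at least 6.4-fold higher number from compound 2 to compound 4 (0.81 log units; beyond the scatter) with the urea linkage unchanged. Unlike the step from compound 1 to compound 2, this step changes the aryl group alone. Going by these compounds, compound 4 reaches only a limit, so the true size of the step stays open: the limit of > 50000 nM in this assay, at which 1 of the 4 values shown sits.

The step between compound 1 and compound 4 cannot be read, both values being limits. On these data alone, whether an aryl group carrying a morpholine or a carboxylic acid keeps the growth inhibition of compound 2 remains open.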